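Aryloxypropoxy acids: compound 1 to compound 3

A few compounds are considered here, and "the series" means these few. Any claim that something is new, unique, unknown or untested is made for them only; others in the source may bear on it.

Compound 1 `Cc1cccc(OCCCOc2ccc(CCC(=O)O)cc2)c1C` sits at the assay limit: in an assay on isolated protein for inhibition of Polyunsaturated fatty acid 5-lipoxygenase (Homo sapiens), read by HPLC, with a stated time of 15 min, in the presence of a further agent that is not named here (a lower number here means a stronger inhibitor, a higher number a weaker inhibitor), compound 1 gives > 10000 nM, a limit rather than a number. Compound 2 `CCCCC(Sc1ccc(OCCCOc2ccc3ncccc3c2)cc1)C(=O)O` also gives only a limit, > 10000 nM, in this assay. Both values shown rest at the limit of > 10000 nM in this assay, at which 2 of the 2 values shown sit. Compound 3 `Cc1cccc(OCCCOc2ccc(SCC(=O)O)cc2)c1C` carries the change ((carboxymethyl)sulfanyl in place of 2-carboxyethyl on an aromatic carbon), (carboxymethyl)sulfanyl in place of 2-carboxyethyl on an aromatic carbon. Within the data shown here, with no measured step to guide direction, compound 3 is expected to remain near the limit, the step that the limit leaves unreadable from compound 1 to compound 3 being an estimate within scatter. Compound 3 is estimated at 15000 nM, between 3000 nM and 60000 nM.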

Compound 3, half-maximal inhibitory concentration: > 10000 nM
Compound 3: no number, only a limit; the forecaster's own chance of this, stated with the estimate: 80%; the middle value is on the limit's open side.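

Among these compounds, compound 3 gives > 10000 nM in this assay, a limit and not a number, so no step from compound 1 to compound 3 can be read. The compounds shown leave open which change, if any, would give a readable value: the limit of > 10000 nM in this assay, at which 3 of the 3 values shown sit.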